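The source may hold more compounds than are shown below. What is called first, only, known or untested is meant among the compounds shown, and "the series" means these compounds.

Measured so far:
compound 1 `COc1cc(OC)c(C(=O)/C=C/c2cn(-c3ccccc3)nc2-c2cccnc2)c(OC)c1` gives 1100 nM
compound 2 `COc1ccc(OC)c(C(=O)/C=C/c2cn(-c3ccccc3)nc2-c2cccnc2)c1` gives 2000 nM

Compound 2 and compound 1 lie within the scatter of each other, so neither stands apart on these two numbers. Compound 3 `COc1ccc(OC)c(C(=O)/C=C/c2cn(-c3ccccc3)nc2-c2ccncc2)c1` keeps the same atoms joined differently: pyridin-4-yl in place of pyridin-3-yl on an aromatic carbon. Going by the values given here, no measured pair shows this change, so in a functional assay on Mahlavu cells (Homo sapiens) for inhibition, read by sulforhodamine B assay, with a stated time of 72 h (on this read-out higher numbers stand for weaker inhibition and lower numbers for stronger inhibition), no step beyond the scatter is expected in either direction. The expected step from compound 2 to compound 3 is no change at the digits printed from compound 2 to compound 3 (within the scatter). Compound 3 is estimated at 2000 nM, with a range of 900 nM to 4500 nM.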

Compound 3, half-maximal inhibitory concentration: 1600 nM
Compound 3: middle estimate off by 1.3-fold (0.10 log units), on the high side; measured number inside the range.
By their numbers in this assay, from the lowest: compounds 1, 3 and 2 (each within the scatter of the next).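

Pyridin-4-yl in place of pyridin-3-yl on the aromatic carbon of the five-membered ring gives a 1.3-fold lower number from compound 2 to compound 3 (0.10 log units; within the scatter) in this assay. Going by these compounds alone, this is the first reading at this position, and on this pair the two pyridine isomers are not told apart. No supporting measurement bears on this result.
Still open, on these data alone, is whether any group at this position moves the number beyond the scatter. Pyridin-2-yl, a plain phenyl, or a phenyl carrying an amine or a carboxylic acid would each test that.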